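The source may hold more compounds than are shown below. What is called first, only, known or untested is meant among the compounds shown, and "the series" means these compounds.

Working notes on the series, read in a functional assay on MiaPaCa cells (Homo sapiens) for antiproliferative activity, read by sulforhodamine B assay, with a stated time of 48 h; a higher number here means a weaker inhibitor of growth, a lower number a stronger inhibitor of growth. Compound 1 `COc1ccc(-c2cn(CCCN3C(=O)COc4ccccc43)nn2)cc1` gives 15700 nM and compound 2 `O=C1COc2ccccc2N1CCCn1cc(CCCCl)nn1` gives 12500 nM. Within the data shown here, the two values lie within the scatter of each other, so compound 2 stands level with the only other measured member.

Compound 3 `O=C1COc2ccccc2N1CCCn1cc(C2(O)CCCCC2)nn1` has not yet been measured. It carries 1-hydroxycyclohexyl in place of 3-chloropropyl on an aromatic carbon of the five-membered aromatic ring with 3 nitrogen: 1-hydroxycyclohexyl in place of 3-chloropropyl on an aromatic carbon.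

Among the measured compounds shown here, one measured step bears on this place. That step, a 1.3-fold lower number from compound 1 to compound 2 (0.10 log units; within the scatter), exchanged 4-methoxyphenyl for 3-chloropropyl on the same carbon. For the measured compounds named here, no measured compound carries 1-hydroxycyclohexyl, so the data do not test this group directly, and a single step is thin support. On that step, no change beyond the scatter is expected in this assay, though the range is kept wide in both directions. The expected change is a 1.0-fold lower number from compound 2 to compound 3 (0.02 log units; within the scatter). Compound 3 is estimated at 12000 nM, with an expected range of 5000 nM to 30000 nM.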

Compound 3, concentration for 50% growth inhibition: 2500 nM
For compound 3 the middle estimate is 4.8-fold (0.68 log units) above the measured one; measured number outside the range, below it.
By their numbers in this assay, from the lowest: compound 3; then compounds 2 and 1 (each within the scatter of the next).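

In this assay this carbon of the five-membered aromatic ring with 3 nitrogen proves able to move the number: a 5.0-fold lower number from compound 2 to compound 3 (0.70 log units; beyond the scatter) and a 6.3-fold lower number from compound 1 to compound 3 (0.80 log units; beyond the scatter) both lie beyond the scatter, while the exchange between the two earlier groups did not show any such separation. Compound 3 thus shows that the position is not indifferent to what it carries, and that 1-hydroxycyclohexyl reads apart from both 3-chloropropyl and 4-methoxyphenyl, though only modestly, and the change brings in the six-membered non-aromatic ring and the hydrogen-bond donor and acceptor together. No measurement at hand accounts for the step.

The compounds shown leave open whether the ring or the hydroxyl carries the step, a question that plain cyclohexyl and a 3-hydroxypropyl chain on the same carbon would separate. They also leave open how an amine or a carboxylic acid at this place would read in this assay and whether the step from 3-chloropropyl to 1-hydroxycyclohexyl holds on any other core.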